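Oxolane Gives Way to Methylamino on the Shared Core

A few compounds are considered here, and "the series" means these few. Any claim that something is new, unique, unknown or untested is made for them only; others in the source may bear on it.

Compound 2 `COc1cc(-c2cnn3cc(OC)c(C4CCOC4)nc23)ccn1` gives 29% in an ADME assay on microsomes from liver (Homo sapiens) for metabolic stability, with a stated time of 60 min, tested at 1 uM (a lower number here means that less of the compound is left, a higher number that more of the compound is left), the lowest of three numbers, with compound 1 `COc1cc(-c2cnn3cc(OC)c(-c4cc(C)no4)nc23)ccn1` at 31% and compound 3 `COc1cn2ncc(-c3ccnc(OC(C)C)c3)c2nc1-c1cnn(C)c1` at 32% both within the scatter of it. Going by the values given here, the single measured step, a number 2 percentage points lower from compound 1 to compound 2 (within the scatter), stayed within the scatter. Compound 4 `CNc1nc2c(-c3ccnc(OC)c3)cnn2cc1OC` differs from compound 2 in one place: methylamino in place of oxolan-3-yl on an aromatic carbon. Among the compounds with values here, no measured step involves methylamino, so the oxolan-3-yl step speaks only to the leaving group. Compound 4 is therefore expected to stay near compound 2, whose 29% anchors the estimate, and is estimated at 35% with a range of 20% to 55%. This expectation amounts to a number 6 percentage points higher from compound 2 to compound 4 (within the scatter).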

Compound 4, percent of the compound remaining: 63%
Estimate against measurement, compound 4: 28 percentage points below; measured number outside the range, above it.
By their numbers in this assay, from the lowest: compounds 2, 1 and 3 (each within the scatter of the next); then compound 4.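

In this assay, this position proves not to be indifferent: exchanging 3-methyl-1,2-oxazol-5-yl for oxolan-3-yl stayed within the scatter, yet methylamino gives a number 34 percentage points higher from compound 2 to compound 4 (beyond the scatter) and a number 32 percentage points higher from compound 1 to compound 4 (beyond the scatter). Both steps are large, so replacing either ring with this smaller, ring-free group goes with more compound remaining. Nothing available accounts for the rise. The compounds shown leave open whether the rise follows the hydrogen-bond donor, the loss of the ring or the lower heavy-atom count, as these changed together. A dimethylamino group, an ethylamino chain or an azetidine here would begin to separate them.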